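Isobutoxy in place of methoxy on the bromomethyl chromone series

The compounds below may be only part of what the source reports. "The series", "measured", "known", "first", "only" and "open" are said of these compounds alone.

Within the data shown here, compound 2 `COc1ccc2c(=O)cc(C(C)Br)oc2c1CBr` is the only member of the series with a number rather than a limit: in a functional assay on KBVIN cells (Homo sapiens) for antiproliferative activity, read by sulforhodamine B assay, with a stated time of 72 h (on this read-out higher numbers stand for weaker inhibition of growth and lower numbers for stronger inhibition of growth), compound 2 gives 17000 nM. Compound 1 `CCc1cc(=O)c2ccc(OC)c(CBr)c2o1` stands only at a limit, since in this assay compound 1 gives > 33600 nM. Among the measured compounds shown here, the one measured step, an at least 1.9-fold lower number from compound 1 to compound 2 (0.29 log units; that floor lies within the scatter), concerns bromo in place of hydrogen on a saturated chain carbon bound to an aromatic carbon and a saturated chain carbon, and rests on (the limit of > 33600 nM in this assay, at which 1 of the 2 values shown sits).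

Compound 3 `CC(C)COc1ccc2c(=O)cc(C(C)Br)oc2c1CBr` differs from compound 2 by isopropyl in place of hydrogen on a saturated chain carbon bound to an oxygen on an aromatic ring; read one bond further out, the change is methoxy to isobutoxy. For the measured compounds named here, no measured step touches this position, so the only guidance is the number of compound 2 and the spread that the scatter allows. No shift beyond the scatter is expected from the step of a 1.1-fold lower number from compound 2 to compound 3 (0.05 log units; within the scatter) in this assay, in either direction. For compound 3 the estimate is therefore 15000 nM, with a range from 5000 nM to 45000 nM in this assay.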

Compound 3, concentration for 50% growth inhibition: 9450 nM
Compound 3: middle estimate off by 1.6-fold (0.20 log units), on the high side, and the stated range covers the measured number.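

Methoxy to isobutoxy, the only change read at this place, gives a 1.8-fold lower number from compound 2 to compound 3 (0.26 log units; within the scatter) in this assay. Isopropyl in place of hydrogen on a saturated chain carbon bound to an oxygen on an aromatic ring, an addition of 3 heavy atoms with no ring, is therefore tolerated in this pair, with the read-out staying within the scatter. This step joins two real numbers, unlike the earlier step in the series, whose floor rests on a limit: the limit of > 33600 nM in this assay, at which 1 of the 3 values shown sits.

On these data alone, whether an amine, a carboxylic acid or a longer chain in place of isobutoxy would move the number beyond the scatter remains open. With a single step at this place, no trend with chain size can be read, and it is also unknown whether the same change would read alike on the core of compound 1, which lacks the second bromo group.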